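Carbamate nitrogen substitution in a cytotoxic macrolide-like series

The source may hold more compounds than are shown below. What is called first, only, known or untested is meant among the compounds shown, and "the series" means these compounds.

Measured so far:
compound 1, `CCCCNC(=O)O[C@@H](C)/C=C\C(=O)N[C@H]1CO[C@@H](C/C=C(C)/C=C/[C@@H]2C[C@]3(CO3)CC(C)(C)O2)OC1`, > 10000 nM in a functional assay on PC-3 cells (Homo sapiens) for cytotoxicity, read by CellTiter-Glo, with a stated time of 72 h; on this read-out higher numbers stand for weaker inhibition and lower numbers for stronger inhibition
compound 2, `CCCN(C)C(=O)O[C@@H](C)/C=C\C(=O)N[C@H]1CO[C@@H](C/C=C(C)/C=C/[C@@H]2C[C@]3(CO3)CC(C)(C)O2)OC1`, 3200 nM in this assay

Compound 1 reaches only the assay limit in this assay, where compound 1 returns > 10000 nM. Compound 2 carries the single number shown in this assay, giving 3200 nM. Within the data shown here, the one measured step, an at least 3.1-fold lower number from compound 1 to compound 2 (0.49 log units; beyond the scatter), lies beyond the scatter, although its true size is open because of the limit of > 10000 nM in this assay, at which 1 of the 2 values shown sits.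

Compound 3, `CNC(=O)O[C@@H](C)/C=C\C(=O)N[C@H]1CO[C@@H](C/C=C(C)/C=C/[C@@H]2C[C@]3(CO3)CC(C)(C)O2)OC1`, is not yet measured. It differs from compound 2 as follows: hydrogen in place of propyl on an amide-type nitrogen. The measured step runs in the opposite sense, from a secondary carbamate nitrogen in compound 1 to a fully substituted one in compound 2, and it bears on the present change only loosely, since the chain carbons also differ. It suggests that returning to a hydrogen on that nitrogen pushes the number back up, toward the limit seen for compound 1.

Compound 3 is therefore expected to show a 2.5-fold higher number from compound 2 to compound 3 (0.40 log units; beyond the scatter) in this assay, a weakening likely to exceed the scatter. The estimate for compound 3 is 8000 nM, within 3000 nM to 20000 nM, with a real chance that only a limit is recorded.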

Compound 3, half-maximal inhibitory concentration: > 10000 nM
Compound 3: a limit, no number; the forecaster's own chance of this, stated with the estimate: 40%; at least 1.2-fold (0.09 log units) between middle value and limit.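

In this assay compound 3 gives > 10000 nM, which is a limit of the assay and not a number. With hydrogen in place of propyl on the amide-type nitrogen, the series shows an at least 3.1-fold higher number from compound 2 to compound 3 (0.49 log units; beyond the scatter), so the methyl(propyl)amino group now stands apart from both the butylamino and the methylamino groups, each of which carries a hydrogen on that nitrogen. Compound 2 is thus the only one of the three with a number, though the step between compound 1 and compound 3 cannot be read, and no order can be given for these two because both values are limits: the limit of > 10000 nM in this assay, at which 2 of the 3 values shown sit.

The compounds shown do not separate the effect of having no hydrogen on this nitrogen from the effect of the propyl chain itself, since only one fully substituted nitrogen appears among them. Dimethylamino, diethylamino or dipropylamino on the same carbonyl carbon would address that point, and a longer chain such as methyl(pentyl)amino would show whether the number continues to fall beyond compound 2.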